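This account rests on a few compounds, and the source may have more. Where it says the series, first, only, none or still open, it means among the compounds named here.

- compound 1 `COC(=O)CN(C)Cc1c(OC)cc(OC)c(C(=O)/C=C/c2ccccc2Cl)c1O`: 8500 nM
- compound 2 `CCN(CC)Cc1c(OC)cc(OC)c(C(=O)/C=C/c2ccccc2Cl)c1O`: 6700 nM

Both values come from a functional assay on Bel-7402 cells (Homo sapiens) for antiproliferative activity, with a stated time of 72 h; on this read-out higher numbers stand for weaker inhibition and lower numbers for stronger inhibition. With only these two numbers to compare, compound 2 stands level with compound 1, as the step between them is a 1.3-fold lower number from compound 1 to compound 2 (0.10 log units; within the scatter). The next compound, compound 3 `COc1cc(OC)c(C(=O)/C=C/c2ccccc2Cl)c(O)c1CN(C)C`, has not yet been measured. It keeps the shared core of compound 2 and differs in a single group: dimethylamino in place of diethylamino on a saturated chain carbon bound to an aromatic carbon. Put simply, dimethylamino sits in place of diethylamino on a saturated chain carbon bound to an aromatic carbon.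

Among the measured compounds shown here, the one measured step between compound 1 and compound 2 bears on this change, as it also swaps a group at that place, and it stayed within the scatter. For the measured compounds named here, a single step is thin evidence, and no measured compound yet carries dimethylamino, so the range has to stay wide. In this assay, no step beyond the scatter is expected. The expected change is a 1.0-fold lower number from compound 2 to compound 3 (0.01 log units; within the scatter). Compound 3 is estimated at 6500 nM, with an expected range from 2800 nM to 15000 nM.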

Compound 3, half-maximal inhibitory concentration: 21800 nM
For compound 3 the middle estimate is 3.4-fold (0.53 log units) below the measured one; the measured number lies above the stated range.
By their numbers in this assay, from the lowest: compounds 2 and 1 (each within the scatter of the next); then compound 3.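

The place on the saturated chain carbon bound to an aromatic carbon turns out not to be indifferent to the amine it carries: the earlier swap there stayed within the scatter, but going from diethylamino, with 5 heavy atoms, to dimethylamino, with 3, gives a 3.3-fold higher number from compound 2 to compound 3 (0.51 log units; beyond the scatter) in this assay. The step from the other measured amine points the same way, with hydrogen in place of methoxycarbonyl giving a 2.6-fold higher number from compound 1 to compound 3 (0.41 log units; beyond the scatter), so compound 3 sits apart from compound 1 and compound 2, which stay level with each other, and inhibition is weaker with dimethylamino at this place. These steps are modest and the pattern rests on just these three compounds, while nothing available explains why the number rises when these groups change.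

On these data alone, whether the number would stay level or shift again with a longer chain on the nitrogen, such as dipropylamino, remains open. So does the effect of a primary amine at this place, or of a carboxylic acid in place of the methoxycarbonyl group of compound 1.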